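Methyl on the terminal phenyl: compound 3 to compound 4

The source may report more compounds than this note shows. Statements on the series, on what has been measured and on what is new or still open speak of the compounds shown alone.

The series shares a bis-benzimidazole core. Compound 1 `Cc1cccc(-c2nc3cc(-c4nc5cc(C#N)ccc5[nH]4)ccc3[nH]2)c1` carries a nitrile and in a functional assay on RPMI 8402 cells (Homo sapiens) for cytotoxicity (a higher number here means a weaker inhibitor, a lower number a stronger inhibitor), compound 1 gives 860 nM. Compound 2 `Cc1cccc(-c2nc3cc(-c4nc5cc(C(N)=O)ccc5[nH]4)ccc3[nH]2)c1` replaces that nitrile with an amide; in this assay compound 2 gives 8200 nM, and the step of a 9.5-fold higher number from compound 1 to compound 2 (0.98 log units; beyond the scatter). Compound 3 `CN1CCN(c2ccc3[nH]c(-c4ccc5[nH]c(-c6ccccc6)nc5c4)nc3c2)CC1` carries a methylpiperazine on one benzimidazole and an unsubstituted phenyl on the other; in this assay compound 3 gives 490 nM. Among the three numbers compound 3 and compound 1 cannot be told apart within the scatter, while compound 2 lies beyond the scatter above both.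

Compound 4 `Cc1cccc(-c2nc3cc(-c4nc5cc(N6CCN(C)CC6)ccc5[nH]4)ccc3[nH]2)c1` keeps the methylpiperazine of compound 3 and differs only by methyl in place of hydrogen on an aromatic carbon, read one bond further out as phenyl to 3-methylphenyl. Among the measured compounds shown here, no measured step touches this position: the only step available, nitrile to amide, concerns the other end of the molecule. With nothing to build on, no step beyond the scatter is expected, so a 1.0-fold higher number from compound 3 to compound 4 (0.01 log units; within the scatter) is the expectation for compound 4. Compound 4 is therefore estimated at 500 nM, with a range from 200 nM to 1300 nM.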

Compound 4, half-maximal inhibitory concentration: 360 nM
Beside the measured number, compound 4's estimate is 1.4-fold (0.14 log units) above it; the measured number falls inside the stated range.
By their numbers in this assay, from the lowest: compounds 4, 3 and 1 (each within the scatter of the next, the first and the last beyond it); then compound 2.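

In this assay, among the compounds shown here, phenyl to 3-methylphenyl is the only measured change at this position, and adding the methyl leaves the number within the scatter (a 1.4-fold lower number from compound 3 to compound 4 (0.13 log units; within the scatter)). With 3-methylphenyl held fixed, the group at the other end of the molecule can now be compared: 4-methylpiperazin-1-yl in place of carbamoyl gives a large step (a 23-fold lower number from compound 2 to compound 4 (1.36 log units; beyond the scatter)), and in place of cyano a modest one beyond the scatter (a 2.4-fold lower number from compound 1 to compound 4 (0.38 log units; beyond the scatter)). No evidence bearing on these steps is at hand.

On these data alone, whether an ethyl, a methoxy or a carboxylic acid on the phenyl would move the number beyond the scatter remains open. Also open, as far as these compounds go, is how a primary amine or a longer aminoalkyl chain at the other end would compare with 4-methylpiperazin-1-yl.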